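Trimming the Aryl Group on a Shared Amine

The source may hold more compounds than are shown below. What is called first, only, known or untested is meant among the compounds shown, and "the series" means these compounds.

Three compounds were measured in a functional assay on ECa-109 cells for inhibition, with ECa-109 cell line (Homo sapiens) as the target, read by sulforhodamine B assay; a lower number here means a stronger inhibitor, a higher number a weaker inhibitor:

Compound 1, `Cc1ccc(NC2=CC(=O)c3c(nc4n3[C@H]3OC[C@@H](O)[C@H]3OC4)C2=O)cc1C`, gives 4090 nM.
Compound 2, `O=C1C=C(Nc2ccc(C(F)(F)F)cc2)C(=O)c2c1nc1n2[C@H]2OC[C@@H](O)[C@H]2OC1`, gives 5500 nM.
Compound 3, `O=C1C=C(Nc2cccc(Cl)c2)C(=O)c2c1nc1n2[C@H]2OC[C@@H](O)[C@H]2OC1`, gives 4690 nM.

All three share one core and differ only in the aryl group carried on the amine nitrogen. Compound 1 has the lowest of the three numbers, yet its gap to compound 3 and its gap to compound 2 both fall within the usual scatter, so no ordering among them can be claimed. Within the data shown here, the one step between neighbours that differ in a single place, a 1.2-fold lower number from compound 2 to compound 3 (0.07 log units; within the scatter), is itself within the scatter: swapping one aryl group for another left the number essentially unchanged.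

Compound 4, `O=C1C(Nc2ccccc2)=CC(=O)c2c1nc1n2[C@H]2OC[C@@H](O)[C@H]2OC1`, has not yet been measured. It differs from compound 1 in one place: phenyl in place of 3,4-dimethylphenyl on an amine nitrogen. Among the measured compounds shown here, no measured pair shows exactly this change, and the only comparable aryl swap, a 1.2-fold lower number from compound 2 to compound 3 (0.07 log units; within the scatter), was flat. On that basis compound 4 is expected to give a number close to that of compound 1, with a 1.2-fold higher number from compound 1 to compound 4 (0.07 log units; within the scatter) as the estimated step. The estimate for compound 4 is therefore 4800 nM, with a likely range from 2000 nM to 11000 nM.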

Compound 4, half-maximal inhibitory concentration: 3560 nM
The estimate for compound 4 lay 1.3-fold (0.13 log units) above the measured number; measured number inside the range.
By their numbers in this assay, from the lowest: compounds 4, 1, 3 and 2 (each within the scatter of the next).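

Taking the aryl group on the amine nitrogen down to bare phenyl, with both methyl groups of the 3,4-dimethylphenyl gone, gives a step in this assay of a 1.1-fold lower number from compound 1 to compound 4 (0.06 log units; within the scatter). The earlier step only exchanged one substituted aryl group for another, whereas this one shows that a phenyl ring with no substituents at all cannot be told apart from the 3,4-dimethylphenyl compound at this position, so these two methyl groups make no readable difference in this assay. Nothing shown here offers any measured explanation for why the number holds steady across this change.

What remains open is whether this position is tolerant of any group or only of aryl rings of this kind, since every group shown on the amine nitrogen is a six-membered aromatic ring of carbon only. A pyridine ring, a cyclohexyl group, a longer alkyl chain or an aryl group bearing a carboxylic acid or a basic amine would test that, and the compounds shown give no indication of whether any of these would move the number beyond the scatter.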